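Swapping the acid-bearing ring in a desaturase inhibitor series

A few compounds are considered here, and "the series" means these few. Any claim that something is new, unique, unknown or untested is made for them only; others in the source may bear on it.

Compound 3 `O=C(O)c1cncc(-c2ccc(N3CCC(Oc4cc(F)ccc4Br)CC3)nn2)n1` gives 772 nM in an assay on isolated protein for inhibition of acyl-CoA desaturase 1 (Rattus norvegicus) (on this read-out lower numbers stand for stronger inhibition and higher numbers for weaker inhibition), the highest of the three numbers measured here. Among the compounds with values here, compound 1 `O=C(O)c1cncc(-c2ccc(N3CCC(Oc4ccccc4C(F)(F)F)CC3)nn2)c1` gives 129 nM in this assay, and compound 2 `O=C(O)c1cncc(-c2ccc(N3CCC(Oc4ccccc4Cl)CC3)nn2)c1` gives 166 nM; the only single-point step among them, a 1.3-fold higher number from compound 1 to compound 2 (0.11 log units; within the scatter), concerns a different aromatic carbon and says nothing about the acid-bearing part. Compound 4 `O=C(O)Cc1cncc(-c2ccc(N3CCC(Oc4cc(F)ccc4Br)CC3)nn2)c1` differs from compound 3 by a group of 10 heavy atoms (7 carbon, 1 nitrogen, 2 oxygen; one six-membered aromatic ring with 1 hetero atom) in place of a group of 9 heavy atoms (5 carbon, 2 nitrogen, 2 oxygen; one six-membered aromatic ring with 2 hetero atoms), on an aromatic carbon. Within the data shown here, no measured step touches this change, so its direction is open; compounds 1 and 2, which also carry one six-membered aromatic ring with 1 hetero atom in this part of the structure, have the lower numbers, which loosely hints at a lower number for compound 4. Compound 4 is therefore expected to give 350 nM in this assay, a step of a 2.2-fold lower number from compound 3 to compound 4 (0.34 log units; beyond the scatter), within a range from 70 nM to 1800 nM.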

Compound 4, half-maximal inhibitory concentration: 20 nM
Beside the measured number, compound 4's estimate is 18-fold (1.24 log units) above it, and the stated range ends above it.
By their numbers in this assay, from the lowest: compound 4; then compounds 1 and 2 (each within the scatter of the next); then compound 3.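

Within the data shown here, this is the first measured step at this position of the shared core, and it is large: in this assay there is a 39-fold lower number from compound 3 to compound 4 (1.59 log units; beyond the scatter). The entering group differs from 6-carboxypyrazin-2-yl in two ways at once, with a six-membered aromatic ring holding 1 hetero atom rather than 2 and a larger count of heavy atoms, so this one step cannot assign the drop to either difference. On these data alone, whether a longer chain ending in a carboxylic acid, or an amide in place of the acid, would hold this low number remains open. Nothing measured here explains the size of the step.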